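Series notes: pyridin-4-yl in place of carbamoyl

The source may report more compounds than this note shows. Statements on the series, on what has been measured and on what is new or still open speak of the compounds shown alone.

Compound 3 `NC(=O)[C@H]1C[C@@H](c2coc3ccccc3c2=O)N(c2ccccc2)O1` returns in a functional assay on THP-1 cells (Homo sapiens) for inhibition, read by sulforhodamine B assay, with a stated time of 48 h (on this read-out lower numbers stand for stronger inhibition and higher numbers for weaker inhibition), only a limit, > 60000 nM. Compound 1 `Cc1ccc2occ([C@@H]3C[C@H](c4ccccc4)ON3c3ccccc3)c(=O)c2c1` likewise gives in this assay only a limit, > 60000 nM. Compound 2 `CCO[C@H]1C[C@@H](c2coc3cc(Cl)c(Cl)cc3c2=O)N(c2ccccc2)O1` gives in this assay a number, 16500 nM. Among the measured compounds shown here, compound 3 therefore stands at the limit of > 60000 nM in this assay, at which 2 of the 3 values shown sit; no measured step links it to another compound, and against compound 2 the two values show only that one is a number and the other a limit.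

Compound 4 `O=c1c([C@@H]2C[C@H](c3ccncc3)ON2c2ccccc2)coc2ccccc12` is the analogue of compound 3 with pyridin-4-yl in place of carbamoyl on a saturated ring carbon. Compound 1 already carries a phenyl group on a saturated ring carbon of the same kind and also sits at the limit, so an aromatic group at that place has so far not produced a number. Compound 4 is therefore expected to move little, and the expected step of an at least 1.2-fold lower number from compound 3 to compound 4 (0.07 log units; that floor lies within the scatter) is taken as within the scatter. Compound 4 is estimated at 50000 nM, with a range from 15000 nM to 150000 nM, and a limit rather than a number is the likelier outcome.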

Compound 4, half-maximal inhibitory concentration: 16400 nM
Estimate against measurement, compound 4: 3.0-fold (0.48 log units) above; the range from low to high includes it.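

Pyridin-4-yl in place of carbamoyl on a saturated ring carbon, next to the ring oxygen, gives an at least 3.6-fold lower number from compound 3 to compound 4 (0.56 log units; beyond the scatter). Among the compounds shown here, this is the first single change to show that this position can affect the read-out, moving a compound from a limit to a number in this assay. The size of the step is only a floor, and the value of compound 3 remains a limit, a case that recurs among the compounds shown: the limit of > 60000 nM in this assay, at which 2 of the 4 values shown sit.

On these data alone, whether the gain depends on the ring nitrogen of pyridin-4-yl or on the aromatic ring alone stays open, and a phenyl group on the core of compound 4 would separate the two. As far as these compounds go, how an amine, a carboxylic acid or a longer alkyl chain at this place would read in this assay is also open.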